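This account rests on a few compounds, and the source may have more. Where it says the series, first, only, none or still open, it means among the compounds named here.

Three measured compounds set the scene. Compound 1 `O=c1[nH]c(=O)n([C@H]2C[C@H](O)[C@@H](COP(=O)(O)O)O2)cc1Br` gives 26 ug/mL in a functional assay (Raji cells) for antiproliferative activity, with Homo sapiens as the target; on this read-out higher numbers stand for weaker inhibition and lower numbers for stronger inhibition. Compound 3 `O=c1[nH]c(=O)n([C@H]2C[C@H](O)[C@@H](CO)O2)cc1Cl` gives 8.54 ug/mL in the same test. Compound 2 `O=c1[nH]c(=O)n([C@H]2C[C@@H]3O[PH](O)(O)OC[C@H]3O2)cc1F` gives 0.164 ug/mL, the lowest of the three numbers, and so the strongest inhibitor among them: compound 3 stands a good way above it and compound 1 further still, both gaps well beyond the usual scatter of repeated runs.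

Compound 4 `O=c1[nH]c(=O)n([C@H]2C[C@@H]3O[PH](O)(O)OC[C@H]3O2)cc1C(F)(F)F` has not yet been measured. It differs from compound 2 in one place only: trifluoromethyl in place of fluoro on an aromatic carbon. Within the data shown here, no measured pair in this set differs by exactly this change, so nothing here tells directly how large the step will be. Compound 1 and compound 3 differ from compound 2 in more than one place, so their higher numbers cannot be credited to any single change. With that caveat, the expected step from compound 2 to compound 4 is a 6.1-fold higher number from compound 2 to compound 4 (0.79 log units; beyond the scatter), a move toward weaker inhibition, though the uncertainty is wide. Compound 4 is therefore estimated at 1 ug/mL, with a likely range from 0.15 ug/mL to 8 ug/mL.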

Compound 4, concentration for 50% inhibition: 1.81 ug/mL
The estimate for compound 4 lay 1.8-fold (0.26 log units) below the measured number; low and high end bracket the measured number.
By their numbers in this assay, from the lowest: compound 2; then compound 4; then compound 3; then compound 1.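

Here, for the first time in this set, a single change can be read on its own: trifluoromethyl in place of fluoro on an aromatic carbon brings an 11-fold higher number from compound 2 to compound 4 (1.04 log units; beyond the scatter) in this assay and so a large move toward weaker inhibition. The position is therefore not indifferent to what it carries, since replacing a group of 1 heavy atom with one of 4 heavy atoms, with no hydrogen-bond donors or acceptors and no net charge on either group, is enough to shift the result well beyond the usual scatter. Nothing shown here gives a measured reason for this step.

From the compounds shown here alone, a single pair cannot show how the number changes across other groups at this position, so it remains open where a methyl, a nitrile or an amine would fall on the same core. Going by these compounds, it also remains open whether the same change would bring a step of similar size on the cores of compound 1 and compound 3, which differ from compound 2 in more than one place.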